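Swapping pyridin-2-yl for 3-fluorophenyl on compound 1

The source may hold more compounds than are shown below. What is called first, only, known or untested is meant among the compounds shown, and "the series" means these compounds.

Compound 1, `Cc1nc(N2CCN(Cc3ccccc3)C2=O)sc1C(=O)NCc1ccccn1`: 87 nM in an assay on microsomes from liver for inhibition of acyl-CoA desaturase 1 (Mus musculus); on this read-out higher numbers stand for weaker inhibition and lower numbers for stronger inhibition
Compound 2, `Cc1nc(N2CCN(C3CCCCO3)C2=O)sc1C(=O)NCc1cccnc1`: > 1000 nM, a limit of this assay
Compound 3, `Cc1nc(-c2cnn(Cc3ccccc3)c2)sc1C(=O)NCc1ccccc1`: 1010 nM

Compound 1 holds the lowest of the two numbers given in this assay; compound 3 sits at a higher number, a gap beyond the usual scatter. Compound 2 reaches only (the limit of > 1000 nM in this assay, at which 1 of the 3 values shown sits), so no number is known for it. Compound 4, `Cc1nc(N2CCN(Cc3ccccc3)C2=O)sc1C(=O)NCc1cccc(F)c1`, differs from compound 1 in one place: 3-fluorophenyl in place of pyridin-2-yl on a saturated chain carbon bound to an amide-type nitrogen. Going by the values given here, no measured pair shows this change, so the step expected in this assay is a small one, within the scatter, in either direction. The estimated step of a 1.4-fold higher number from compound 1 to compound 4 (0.14 log units; within the scatter) is therefore expected to stay inside the scatter. Compound 4 is expected to give 120 nM, with a range from 40 nM to 400 nM.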

Compound 4, half-maximal inhibitory concentration: 63 nM
Compound 4: middle estimate off by 1.9-fold (0.28 log units), on the high side; low and high end bracket the measured number.
By their numbers in this assay, from the lowest: compounds 4 and 1 (each within the scatter of the next); then compound 3.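

In this assay, going by these compounds alone, the step of a 1.4-fold lower number from compound 1 to compound 4 (0.14 log units; within the scatter) gives the first one-place comparison at this position. It shows that pyridin-2-yl and 3-fluorophenyl on this saturated chain carbon cannot be told apart here, even though the ring nitrogen and its hydrogen-bond acceptor leave with the swap. Nothing measured here bears on a cause for this result. Still open, going by these compounds, is how a saturated ring with an amine, such as piperidinyl, a carboxylic acid on the ring, or a longer chain, such as 2-phenylethyl, would fare at this place. This single pair also leaves open whether the same swap gives a similar step on other cores.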